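Two Aryl-Ether Chains, Two Oxolane Rings, One Shared Change

This account rests on a few compounds, and the source may have more. Where it says the series, first, only, none or still open, it means among the compounds named here.

Measured so far:
compound 1 `COc1cccc(OC/C=C(\C)CC/C=C(\C)C2CC(=O)C(C)(C)O2)c1` gives 33.8 ug/mL
compound 2 `C/C(=C\COc1ccc2ccccc2c1)CC/C=C(\C)C1CC(=O)C(C)(C)O1` gives 26.9 ug/mL
compound 3 `COc1cccc(OC/C=C(\C)CC/C=C(\C)C2=CC(=O)C(C)(C)O2)c1` gives 35.9 ug/mL

All three were tested in a functional assay (Homo sapiens) for inhibition; on this read-out higher numbers stand for weaker inhibition and lower numbers for stronger inhibition. Compound 1 and compound 3 differ in a single place: a group of 8 heavy atoms (6 carbon, 2 oxygen; one five-membered non-aromatic ring with 1 hetero atom) in place of a group of 8 heavy atoms (6 carbon, 2 oxygen; one five-membered non-aromatic ring with 1 hetero atom), on a double-bonded chain carbon bound to a double-bonded chain carbon and a saturated chain carbon. The step of a 1.1-fold higher number from compound 1 to compound 3 (0.03 log units; within the scatter) is small, so the two numbers are not told apart. Compound 2 carries a different aryl ether at the far end of the chain; the difference between the core of compound 1 and the core of compound 2 is not broken down here, and their values in this assay sit close to each other.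

Compound 4 `C/C(=C\COc1ccc2ccccc2c1)CC/C=C(\C)C1=CC(=O)C(C)(C)O1` has not been measured. It stands to compound 2 as compound 3 stands to compound 1: a group of 8 heavy atoms (6 carbon, 2 oxygen; one five-membered non-aromatic ring with 1 hetero atom) in place of a group of 8 heavy atoms (6 carbon, 2 oxygen; one five-membered non-aromatic ring with 1 hetero atom), on a double-bonded chain carbon bound to a double-bonded chain carbon and a saturated chain carbon, at the same place on the chain, so it is the same change. Because a 1.1-fold higher number from compound 1 to compound 3 (0.03 log units; within the scatter) was within the scatter, the step of a 1.1-fold higher number from compound 2 to compound 4 (0.03 log units; within the scatter) is expected to be equally small. Compound 4 is therefore estimated at 28.5 ug/mL, with a range from 17 ug/mL to 48 ug/mL expected.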

Compound 4, half-maximal inhibitory concentration: 51.6 ug/mL
Estimate against measurement, compound 4: 1.8-fold (0.26 log units) below; the measured number lies above the stated range.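

In this assay, the new step is a 1.9-fold higher number from compound 2 to compound 4 (0.28 log units; within the scatter), so swapping the 5,5-dimethyl-4-oxooxolan-2-yl group for the ring with the extra double bond gives two numbers that are not told apart on this core either. Set beside the earlier step, the same change reads alike on both cores, and the two steps themselves cannot be separated: the same change on two cores in this assay, a 1.1-fold higher number (0.03 log units; within the scatter) from compound 1 to compound 3 and a 1.9-fold higher number (0.28 log units; within the scatter) from compound 2 to compound 4, 1.8-fold (0.26 log units) apart, within the scatter of two such steps. This supports carrying the change between these two cores with no clear difference in the read-out, but two pairs do not make a rule for the series, and they do not show that the change would stay this small on every other core.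

The compounds shown leave open whether the same change stays as small when an amine or a carboxylic acid stands at the far end of the chain in place of the aryl ether. They also leave open how it behaves on a longer chain.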